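Swapping the ring on sulfur in a quinoxaline-type series

The source may hold more compounds than are shown below. What is called first, only, known or untested is meant among the compounds shown, and "the series" means these compounds.

Measured compounds:
compound 1, `Nc1cc(N)c2nc(-c3ccccc3)c(NCc3ccc(Cl)c(Cl)c3)nc2c1`, 13500 nM
compound 2, `CCOC(=O)[C@H](CCC(=O)O)NC(=O)c1ccc(Sc2nc3cc(N)cc(N)c3nc2-c2ccccc2)cc1`, 39800 nM
compound 3, `Nc1cc(N)c2nc(-c3ccccc3)c(Sc3ccc(F)cc3)nc2c1`, 34700 nM

The three compounds share a core and were tested in a functional assay on OVCAR-8 cells (Homo sapiens) for inhibition, read by sulforhodamine B assay, with a stated time of 48 h; on this read-out higher numbers stand for weaker inhibition of growth and lower numbers for stronger inhibition of growth. Among them compound 3 has the second highest number of the three, with 34700 nM. Compound 2 lies nearest to it, and the two numbers sit within the usual scatter, so no order can be drawn between compound 3 and compound 2. Compound 1 is the furthest away from compound 3, with a lower number that lies beyond the scatter.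

Compound 4, `Nc1cc(N)c2nc(-c3ccccc3)c(Sc3ccc(Cl)c(Cl)c3)nc2c1`, has not yet been measured. It differs from compound 3 in one place: 3,4-dichlorophenyl in place of 4-fluorophenyl on a sulfur. Within the data shown here, no step between two measured compounds carries exactly this change, so the expectation rests on the values alone. Compound 1 also carries a 3,4-dichlorophenyl group and shows the lowest number of the three, yet its link to the core differs, so it is only a loose guide.

For compound 4 a modest step toward stronger inhibition is expected, a 1.7-fold lower number from compound 3 to compound 4 (0.24 log units; within the scatter), with a fair chance that it stays within the scatter of compound 3. The estimated value for compound 4 is 20000 nM, in a range from 7000 nM to 60000 nM.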

Compound 4, concentration for total growth inhibition: < 100000 nM
Compound 4: no number, only a limit; the forecaster's own chance of this, stated with the estimate: 5%; the middle value does not contradict the limit.
By their numbers in this assay, from the lowest: compound 1; then compounds 3 and 2 (each within the scatter of the next).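

Compound 4 gives no number, only a limit of the assay: the limit of < 100000 nM in this assay, at which 1 of the 4 values shown sits.

The step from compound 3 to compound 4 therefore cannot be read. The compounds shown leave open whether 3,4-dichlorophenyl in place of 4-fluorophenyl on a sulfur changes growth inhibition at all, and if it does, in which direction and by how much.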